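Mixed chloro and methyl pattern on the shared core

The source may report more compounds than this note shows. Statements on the series, on what has been measured and on what is new or still open speak of the compounds shown alone.

Compound 1 `O=C1CC(c2nc(-c3cccc(Cl)c3)no2)CN1c1ccc(Cl)cc1`: 140 nM
Compound 2 `Cc1ccc(N2CC(c3nc(-c4cccc(C)c4)no3)CC2=O)cc1`: 1300 nM

For the measured compounds named here, in an in vitro functional assay on HEK293-A cells for positive allosteric modulation of metabotropic glutamate receptor 5 (Homo sapiens), read by FLIPR and calcium flux (on this read-out lower numbers stand for an effect already at smaller amounts and higher numbers for an effect only at larger amounts of compound), compound 2 gives 1300 nM, the highest of the two numbers so far; compound 1 gives 140 nM, a gap beyond the scatter. Compound 3 `Cc1cccc(-c2noc(C3CC(=O)N(c4ccc(Cl)cc4)C3)n2)c1` carries the change (chloro in place of methyl on an aromatic carbon), chloro in place of methyl on an aromatic carbon, while the other ring keeps its methyl. Compound 3 therefore sits between the two measured compounds in its substituents. The step of a 2.9-fold lower number from compound 2 to compound 3 (0.46 log units; beyond the scatter) is expected to lower the number beyond the scatter. For compound 3 a value of 450 nM is expected, within 180 nM to 1100 nM.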

Compound 3, half-maximal effective concentration: 170 nM
The estimate for compound 3 lay 2.6-fold (0.42 log units) above the measured number, and the stated range ends above it.
By their numbers in this assay, from the lowest: compounds 1 and 3 (each within the scatter of the next); then compound 2.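

In this assay, the 4-methylphenyl to 4-chlorophenyl change is the step that counts (a 7.6-fold lower number from compound 2 to compound 3 (0.88 log units; beyond the scatter)), so this position on the ring at the lactam nitrogen accounts for the gap first seen between compound 1 and compound 2. On the other aromatic ring, the matching swap does not separate the two compounds (a 1.2-fold higher number from compound 1 to compound 3 (0.08 log units; within the scatter)). Nothing shown gives a reason for either step. Still open, on these data alone, is whether a 4-methylphenyl at the first position would respond in the same way with chloro on the other ring, and how a methoxy group or an amine would fare at that position.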